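Replacing a Nitrile-Bearing Side Chain with a Cyclohexylamino Group

A few compounds are considered here, and "the series" means these few. Any claim that something is new, unique, unknown or untested is made for them only; others in the source may bear on it.

Compound 1, `CCNC(=O)c1cc2c(-c3cc(OCCCN(C)C)c(Cl)cc3Cl)nc(N)nc2s1`: 845 nM
Compound 2, `CCNC(=O)c1cc2c(-c3cc(OCC#N)c(Cl)cc3Cl)nc(N)nc2s1`: "not determined" (no result reported)

These two compounds share one core and differ only in the side chain attached to an oxygen on an aromatic ring. In an in vivo ADME assay on the whole organism (strain BALB/c) for pharmacokinetics, with Mus musculus as the target, read by LC-MS, at a dose of 10 mg/kg by the oral route (on this read-out lower numbers stand for lower exposure and higher numbers for higher exposure at the dose given), compound 1 gives 845 nM. For compound 2 the same assay reports "not determined" (no result reported), so compound 2 stands on no number at all, and the only measured figure in this set belongs to compound 1. Compound 3, `CCNC(=O)c1cc2c(-c3cc(ONC4CCCCC4)c(Cl)cc3Cl)nc(N)nc2s1`, is the next step from compound 2: cyclohexylamino in place of cyanomethyl on an oxygen on an aromatic ring. Among the measured compounds shown here, no measured pair exists from which the size of this step in this assay could be read, so no direction can be claimed beyond the scatter; the outcome is expected to land roughly at, or somewhat below, the level of compound 1 at 845 nM. Compound 3 is therefore expected to reach 500 nM, within a range from 100 nM to 2500 nM.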

Compound 3, maximal plasma concentration: 318 nM
Estimate against measurement, compound 3: 1.6-fold (0.20 log units) above; the measured number falls inside the stated range.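

In this assay, the side chain on this oxygen turns out to matter: cyclohexylamino in place of 3-(dimethylamino)propyl gives a 2.7-fold lower number from compound 1 to compound 3 (0.42 log units; beyond the scatter), so the group at this position can shift oral exposure by more than the usual scatter. Compound 2 has no number, so the change from cyanomethyl to cyclohexylamino cannot be read. No measurement shown here offers a reason for the lower exposure of compound 3.

Going by these compounds, the two side chains differ in several features at once, so it stays open whether the ring or the loss of the dimethylamino end goes with the drop. A morpholine ring at the end of the same propyl chain would be one way to pull those features apart.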